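This account rests on a few compounds, and the source may have more. Where it says the series, first, only, none or still open, it means among the compounds named here.

Compound 3 `C1=C(CS/C(=N\C2CCCCC2)NC2CCCC2)N2CCN=C2S1` gives the highest number of the three compounds in a functional assay on CCRF-CEM cells for inhibition of C-X-C chemokine receptor type 4 (Homo sapiens), read by calcium flux (a lower number here means a stronger inhibitor, a higher number a weaker inhibitor), at 173 nM. Compound 1 `C1=C(CS/C(=N\C2CCCCC2)NC2CCCCCC2)N2CCN=C2S1` gives 6.6 nM in this assay, and compound 2 `C1=C(CS/C(=N\C2CCCCC2)NC2CCCCCCC2)N2CCN=C2S1` gives 8 nM. The two measured steps that reach compound 3 are both large: a 26-fold higher number from compound 1 to compound 3 (1.42 log units; beyond the scatter) and a 22-fold higher number from compound 2 to compound 3 (1.33 log units; beyond the scatter). The step of a 1.2-fold higher number from compound 1 to compound 2 (0.08 log units; within the scatter) is the only other one available.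

Compound 4 `C1=C(CS/C(=N\C2CCCCC2)Nc2ccccc2)N2CCN=C2S1` differs from compound 3 in one place: phenyl in place of cyclopentyl on an amine nitrogen. For the measured compounds named here, none of the measured steps exchanges a non-aromatic ring for an aromatic one; they only compare non-aromatic rings of different sizes on the same amine nitrogen, and within those the five-membered ring sits far above the seven- and eight-membered ones. Going by the values given here, the phenyl ring is six-membered, which no measured compound shows. The step from compound 3 to compound 4 is therefore expected to be modest and uncertain, a 1.4-fold lower number from compound 3 to compound 4 (0.16 log units; within the scatter). Compound 4 is estimated at 120 nM in this assay, within a range from 25 nM to 600 nM.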

Compound 4, half-maximal inhibitory concentration: 5280 nM
Compound 4: the middle estimate sits 44-fold (1.64 log units) below what was measured; measured number outside the range, above it.
By their numbers in this assay, from the lowest: compounds 1 and 2 (each within the scatter of the next); then compound 3; then compound 4.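

In this assay, phenyl on the amine nitrogen gives the largest steps seen so far: a 31-fold higher number from compound 3 to compound 4 (1.48 log units; beyond the scatter), a 660-fold higher number from compound 2 to compound 4 (2.82 log units; beyond the scatter) and an 800-fold higher number from compound 1 to compound 4 (2.90 log units; beyond the scatter). Ring size alone therefore does not order these compounds: among compounds 1, 2 and 3 the five-membered non-aromatic ring gave the highest number, yet compound 4, with its six-membered aromatic ring, stands above compound 3 and goes against that pattern. Nothing available explains why the aromatic ring behaves this way.

The compounds shown leave open how a cyclohexyl ring would read on this amine nitrogen, a comparison that would set a six-membered non-aromatic ring against phenyl directly. They also leave open whether a benzyl group there would read closer to compound 4 or to compound 3.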